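Nitro on the chloro-bearing ring: expected effect on cytotoxicity

The source may hold more compounds than are shown below. What is called first, only, known or untested is meant among the compounds shown, and "the series" means these compounds.

Measured so far in an ADME assay on RAW264.7 cells (Mus musculus) for cytotoxicity, read by MTT assay, with a stated time of 48 h; on this read-out lower numbers stand for stronger inhibition and higher numbers for weaker inhibition:
Compound 1, `COc1cc(NC(=O)c2ccc(Cl)cc2)ccc1NS(C)(=O)=O`, gives 70000 nM.
Compound 2, `COc1cc(NC(=O)c2ccc(Cl)c([N+](=O)[O-])c2)ccc1NS(C)(=O)=O`, gives > 250000 nM, which is a limit of the assay and not a number.
Compound 3, `COc1cc(NC(=O)c2ccc(Cl)cc2)ccc1NS(=O)(=O)C(F)(F)F`, gives 108000 nM.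

Compound 2 stands at the limit of > 250000 nM in this assay, at which 1 of the 3 values shown sits. The change from compound 1 to compound 2 is nitro in place of hydrogen on an aromatic carbon, and it made an at least 3.5-fold higher number from compound 1 to compound 2 (0.55 log units; beyond the scatter). The two cores differ by trifluoromethyl in place of methyl on a sulfonyl sulfur, a step of a 1.5-fold higher number from compound 1 to compound 3 (0.19 log units; within the scatter).

Compound 4, `COc1cc(NC(=O)c2ccc(Cl)c([N+](=O)[O-])c2)ccc1NS(=O)(=O)C(F)(F)F`, is not yet measured in this assay. It differs from compound 3 by nitro in place of hydrogen on an aromatic carbon, the same change as from compound 1 to compound 2, at the same place. For compound 4 a step of a 3.2-fold higher number from compound 3 to compound 4 (0.51 log units; beyond the scatter) is expected, resting on the measured step of an at least 3.5-fold higher number from compound 1 to compound 2 (0.55 log units; beyond the scatter), and most likely only a limit will be reported. The estimate for compound 4 in this assay is 350000 nM, between 150000 nM and 900000 nM.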

Compound 4, half-maximal inhibitory concentration: > 250000 nM
Compound 4 was reported as a limit (the forecaster's own chance of this, stated with the estimate: 75%); the middle value does not contradict the limit.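

In this assay compound 4 gives > 250000 nM, which is a limit of the assay and not a number, so the trifluoromethyl step from compound 2 to compound 4 cannot be read. On the trifluoromethyl core, nitro in place of hydrogen on an aromatic carbon gave an at least 2.3-fold higher number from compound 3 to compound 4 (0.36 log units; beyond the scatter). The change thus points the same way on both cores shown, but this does not establish that its size carries over, and two cores do not make a rule for the series: the same change on two cores in this assay, an at least 3.5-fold higher number (0.55 log units; beyond the scatter) from compound 1 to compound 2 and an at least 2.3-fold higher number (0.36 log units; beyond the scatter) from compound 3 to compound 4; the limit leaves it open whether they differ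

The compounds shown leave open how an amine or a carboxylic acid would behave in place of the nitro group. They also leave open whether the same step appears with a longer chain on the sulfonyl sulfur.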